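Chloro Substitution on the Aryl Urea: An Ortho Variant

A few compounds are considered here, and "the series" means these few. Any claim that something is new, unique, unknown or untested is made for them only; others in the source may bear on it.

Compound 1 `CN1CC(=O)N/C1=N\C(=O)Nc1ccccc1`: 3300 nM
Compound 2 `Cc1cnccc1NC(=O)/N=C1\NC(=O)CN1C`: 1600 nM
Compound 3 `CN1CC(=O)N/C1=N\C(=O)Nc1ccc(Cl)cc1`: > 5000 nM

For the measured compounds named here, in a functional assay for antagonist activity at metabotropic glutamate receptor 5 (Homo sapiens), read by FLIPR (a higher number here means a weaker inhibitor, a lower number a stronger inhibitor), compound 1 gives 3300 nM, the higher of the two numbers measured so far. Compound 2, whose aryl group carries a methyl and a ring nitrogen, gives 1600 nM, a lower number, and that gap lies beyond the usual scatter. For compound 3 the reported value > 5000 nM is a limit of this assay and not a number.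

Compound 4 `CN1CC(=O)N/C1=N\C(=O)Nc1ccccc1Cl` differs from compound 1 by chloro in place of hydrogen on an aromatic carbon. Going by the values given here, the one measured step of the same kind is an at least 1.5-fold higher number from compound 1 to compound 3 (0.18 log units; that floor lies within the scatter), where chloro entered an aromatic carbon of the same aryl ring, at a different position. That step, anchored at the limit of > 5000 nM in this assay, at which 1 of the 3 values shown sits, points toward a higher number or at most no change beyond the scatter. For compound 4 the expected step is therefore a 1.5-fold higher number from compound 1 to compound 4 (0.18 log units; within the scatter). In this assay compound 4 is estimated at 5000 nM, with a range from 2200 nM to 12000 nM.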

Compound 4, half-maximal inhibitory concentration: 6800 nM
Beside the measured number, compound 4's estimate is 1.4-fold (0.13 log units) below it, within the range that was stated.
By their numbers in this assay, from the lowest: compound 2; then compound 1; then compound 4.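

In this assay, chloro in place of hydrogen on an aromatic carbon, ortho to a large group, gives a 2.1-fold higher number from compound 1 to compound 4 (0.31 log units; beyond the scatter) and so provides a measured size for this change. The earlier chloro compound offered only a floor within the scatter, whereas this step shows that the change can modestly weaken inhibition beyond the scatter at this position. Compound 3 stands at a limit of the assay, so the two chloro positions cannot be ranked against each other: the limit of > 5000 nM in this assay, at which 1 of the 4 values shown sits.

The compounds shown leave open whether fluoro or methoxy at this same position would move the number in the same direction. Going by these compounds, they also leave open what an amine or a carboxylic acid would do there, so the reach of this single chloro step remains unknown.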